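Tert-butyl for methyl at the ketone chain carbon

The source may hold more compounds than are shown below. What is called first, only, known or untested is meant among the compounds shown, and "the series" means these compounds.

Of the compounds shown here, two have been tested in an assay on HEK293 cells for positive allosteric modulation of metabotropic glutamate receptor 3 (Rattus norvegicus), read by thallium flux, with a stated time of 2.5 min; on this read-out higher numbers stand for larger maximal responses and lower numbers for smaller maximal responses. Compound 1, with the structure `Cc1c(OCCCCOc2ccc(F)c(C(=O)O)c2)ccc(C(=O)CC(C)(C)C)c1O`, gives 102%. Compound 2, with the structure `CCC(=O)c1ccc(OCCCCOc2cccc(C(=O)O)c2C)c(C)c1O`, gives 16.3%, the lowest of the two numbers; the gap between it and compound 1 lies beyond the usual scatter, though the two differ in more than one place, so their values are only placed side by side here. Compound 3, with the structure `Cc1c(OCCCCOc2ccc(C(=O)CC(C)(C)C)c(O)c2C)cccc1C(=O)O`, has not yet been measured. It differs from compound 2 in one way: tert-butyl in place of methyl on a saturated chain carbon bound to a carbonyl carbon. Among the measured compounds shown here, compound 1, the only measured compound that carries the neopentylcarbonyl group, gives 102%, and on that basis compound 3 is expected to rise above compound 2 by a step of a number 43.7 percentage points higher from compound 2 to compound 3 (beyond the scatter), well beyond the scatter. Compound 3 is therefore estimated to give 60%, expected to fall between 25% and 100%.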

Compound 3, largest response reached (reported as percent of maximum), in percent of the reference or control that the assay uses: 109%
For compound 3 the middle estimate is 49 percentage points below the measured one; the whole stated range lies below it.
By their numbers in this assay, from the lowest: compound 2; then compounds 1 and 3 (each within the scatter of the next).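

In this assay, the exchange of methyl for tert-butyl on a saturated chain carbon bound to a carbonyl carbon can now be read as a single change, and it gives a number 92.7 percentage points higher from compound 2 to compound 3 (beyond the scatter); the gap seen earlier spanned more than one place, whereas this step ties the difference to this position for this pair. With the neopentylcarbonyl group kept, 3-carboxy-2-methylphenyl in place of 3-carboxy-4-fluorophenyl on an oxygen on a saturated carbon gives a number 7 percentage points higher from compound 1 to compound 3 (within the scatter), so the maximal response does not distinguish these two groups. No measurement beyond these maximal responses bears on why the step from methyl to tert-butyl is so large.

The compounds shown leave open how isopropyl, cyclopropyl or a longer chain would read at the same carbon. They also leave open whether an amine there would preserve the response seen with tert-butyl.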